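Chloro on the benzoyl group of compound 2

A few compounds are considered here, and "the series" means these few. Any claim that something is new, unique, unknown or untested is made for them only; others in the source may bear on it.

Measured compounds:
- Compound 1, `CCCC(=O)N1c2ccccc2CCC1C(=O)Nc1cc(C(F)(F)F)cc(C(F)(F)F)c1`: in a functional assay on PC-3 cells (Homo sapiens) for cytotoxicity, read by sulforhodamine B assay, with a stated time of 72 h (a lower number here means a stronger inhibitor of growth, a higher number a weaker inhibitor of growth), compound 1 gives 18600 nM.
- Compound 2, `O=C(Nc1cc(C(F)(F)F)cc(C(F)(F)F)c1)C1CCc2ccccc2N1C(=O)c1ccccc1`: in this assay compound 2 gives 3500 nM.

Among the compounds with values here, compound 2 holds the lower of the two numbers so far. Within the data shown here, the single measured step, a 5.3-fold lower number from compound 1 to compound 2 (0.73 log units; beyond the scatter), exchanges the whole acyl chain on the ring nitrogen of the shared core and is the only comparison available.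

The next compound is compound 3, `O=C(Nc1cc(C(F)(F)F)cc(C(F)(F)F)c1)C1CCc2ccccc2N1C(=O)c1cccc(Cl)c1`. It differs from compound 2 by chloro in place of hydrogen on an aromatic carbon. Among the measured compounds shown here, no measured step touches a substituent on the benzoyl phenyl; the step from compound 1 to compound 2 concerns the acyl group as a whole and therefore gives no direct guide to adding a chloro to that phenyl. With nothing in the series pointing either way, the working expectation for compound 3 is a step that stays within the usual scatter, perhaps leaning slightly toward a lower number, a 1.4-fold lower number from compound 2 to compound 3 (0.15 log units; within the scatter). Compound 3 is accordingly estimated at 2500 nM in this assay, with an expected range from 900 nM to 7000 nM.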

Compound 3, concentration for 50% growth inhibition: 1050 nM
Estimate against measurement, compound 3: 2.4-fold (0.38 log units) above; the measured number falls inside the stated range.
By their numbers in this assay, from the lowest: compound 3; then compound 2; then compound 1.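

In this assay, within the data shown here, the phenyl of the benzoyl group proves responsive to substitution: chloro in place of hydrogen on an aromatic carbon gives a 3.3-fold lower number from compound 2 to compound 3 (0.52 log units; beyond the scatter), the first measured step that concerns a substituent on this ring rather than the acyl group as a whole. The two changes on the acyl group now reach further together, as 3-chlorophenyl in place of propyl on the carbonyl carbon gives an 18-fold lower number from compound 1 to compound 3 (1.25 log units; beyond the scatter), a large step compared with the modest one for phenyl alone. Nothing at hand accounts for the effect of the chloro on growth inhibition.

On these data alone, a single chloro at one place cannot separate an effect specific to chlorine from one shared by other substituents, so it remains open how fluoro, bromo, methoxy, an amine or a carboxylic acid would behave on this phenyl, or how chloro would behave on its other carbons. All three compounds also keep the same amide partner with its two trifluoromethyl groups, leaving the contribution of that part of the structure untested by these comparisons.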